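A few compounds are considered here, and "the series" means these few. Any claim that something is new, unique, unknown or untested is made for them only; others in the source may bear on it.

In a physicochemical assay for solubility, measured as kinetic solubility, with a stated time of 1 h, at pH 7.4 (on this read-out lower numbers stand for lower solubility and higher numbers for higher solubility), compound 1 (`O=C(Nc1nc(-c2ccc(Cl)c(Cl)c2)cs1)c1c(F)cccc1F`) gives 5000 nM, compound 2 (`CC(=O)NC1=NN(c2ccc(Cl)c(Cl)c2)CC1`) gives 31000 nM, and compound 3 (`O=C(NC1=NN(c2ccc(Cl)c(Cl)c2)CC1)c1ccccn1`) gives 11000 nM, the second highest of these three numbers. Compound 4 (`Cc1ncncc1C(=O)NC1=NN(c2ccc(Cl)c(Cl)c2)CC1`) has not yet been measured. It departs from compound 3 at a single place, on a carbonyl carbon whose other neighbour is an amide-type nitrogen, where 4-methylpyrimidin-5-yl stands in place of pyridin-2-yl: 4-methylpyrimidin-5-yl in place of pyridin-2-yl on a carbonyl carbon.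

Going by the values given here, only one measured step touches this place: a 2.8-fold lower number from compound 2 to compound 3 (0.45 log units; beyond the scatter), a modest change that came with pyridin-2-yl replacing methyl. Among the compounds with values here, it gives a sense of size, but no measured compound carries 4-methylpyrimidin-5-yl, so the direction remains a judgement. A slightly higher number is expected, with no shift clearly beyond the scatter. The estimated change is a 1.5-fold higher number from compound 3 to compound 4 (0.16 log units; within the scatter), smaller than the measured step. Compound 4 is expected at 16000 nM. Its estimated range runs from 7000 nM to 36000 nM.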

Compound 4, solubility: 12000 nM
Estimate against measurement, compound 4: 1.3-fold (0.12 log units) above; measured number inside the range.
By their numbers in this assay, from the lowest: compound 1; then compounds 3 and 4 (each within the scatter of the next); then compound 2.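

In this assay, exchanging pyridin-2-yl for 4-methylpyrimidin-5-yl on this carbonyl carbon gives a 1.1-fold higher number from compound 3 to compound 4 (0.04 log units; within the scatter), so the added ring nitrogen and methyl group leave the read-out within the scatter. Set against methyl, the new group gives a 2.6-fold lower number from compound 2 to compound 4 (0.41 log units; beyond the scatter), which means that both aromatic groups tried at this place now go with lower numbers than methyl. Nothing presented here explains these numbers.

The compounds shown leave open whether a non-aromatic group on this carbonyl carbon, such as a longer alkyl chain, a morpholine or a group carrying a primary amine, would stay with methyl or fall with the two aromatic groups. They also leave open whether a carboxylic acid on the aromatic ring would move the number beyond the scatter.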